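Diterpenoid series: amine to triazole on the exocyclic methylene

This account rests on a few compounds, and the source may have more. Where it says the series, first, only, none or still open, it means among the compounds named here.

Of the compounds shown here, two have been measured in a functional assay on SMMC-7721 cells (Homo sapiens) for antiproliferative activity, read by MTT assay, with a stated time of 48 h; on this read-out higher numbers stand for weaker inhibition and lower numbers for stronger inhibition. Compound 1 `CC(=O)O[C@]1(C)/C=C/C(=O)/C(CO)=C\C[C@](C)(CCC=C(C)C)/C=C/[C@H]1OC(=O)C=C(C)C` gives 3080 nM in this assay. Compound 2 `CC(C)=CCC[C@]1(C)/C=C/[C@@H](OC(=O)C=C(C)C)[C@](C)(O)/C=C/C(=O)/C(CN(C)C)=C\C1` gives 820 nM in this assay and so stands at the lower of the two numbers, with compound 1 the higher by a margin beyond the scatter of repeated measurements. Among the measured compounds shown here, no pair of measured compounds differs in only one place, so no single step is yet established.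

Compound 3 `CC(C)=CCC[C@]1(C)/C=C/[C@@H](OC(=O)C=C(C)C)[C@](C)(O)/C=C/C(=O)/C(Cn2cc(CO)nn2)=C\C1` keeps the core of compound 2 and changes one group, on a saturated chain carbon bound to a double-bonded ring carbon: 4-(hydroxymethyl)-1H-1,2,3-triazol-1-yl in place of dimethylamino on a saturated chain carbon bound to a double-bonded ring carbon. For the measured compounds named here, with no comparable step measured, the expected step is a 2.0-fold higher number from compound 2 to compound 3 (0.29 log units; within the scatter), a modest rise in the number, close to the edge of the scatter. For compound 3 the expected value in this assay is 1600 nM, within a range from 500 nM to 5000 nM.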

Compound 3, half-maximal inhibitory concentration: 3560 nM
For compound 3 the middle estimate is 2.2-fold (0.35 log units) below the measured one; the measured number falls inside the stated range.
By their numbers in this assay, from the lowest: compound 2; then compounds 1 and 3 (each within the scatter of the next).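

In this assay the series now has its first step in a single place: on a saturated chain carbon bound to a double-bonded ring carbon, 4-(hydroxymethyl)-1H-1,2,3-triazol-1-yl in place of dimethylamino gives a 4.3-fold higher number from compound 2 to compound 3 (0.64 log units; beyond the scatter) and so marks a real loss of inhibition. The number therefore depends on the group at this position, and of these two groups dimethylamino gives the stronger inhibition. No measured evidence bears on the reason for this step.

This one step cannot separate the triazole ring from its hydroxymethyl group, nor the loss of dimethylamino from the entry of the new group. Still open, as far as these compounds go, is whether another amine such as pyrrolidine or morpholine, or a triazole carrying a carboxylic acid or a longer chain, would stay close to compound 2 or to compound 3.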